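The source may report more compounds than this note shows. Statements on the series, on what has been measured and on what is new or still open speak of the compounds shown alone.

Measured in a functional assay on MCF7 cells (Homo sapiens) for inhibition, read by sulforhodamine B assay, with a stated time of 48 h; a lower number here means a stronger inhibitor of growth, a higher number a weaker inhibitor of growth:
compound 1 `COc1cc(-c2nn(-c3cccc(NC(=O)c4ccc(Cl)c(C(F)(F)F)c4)c3)cc2-c2ccncc2)ccc1Cl`, 2240 nM
compound 2 `COc1cc(-c2nn(-c3cccc(NC(=O)c4cccc(C(F)(F)F)c4)c3)cc2-c2ccncc2)ccc1Cl`, 1430 nM
compound 3 `O=C(Nc1cccc(-n2cc(-c3ccncc3)c(-c3ccc(Cl)c(O)c3)n2)c1)Nc1cc(C(F)(F)F)cc(C(F)(F)F)c1`, 540 nM

Compound 2 stands second highest of the three numbers: the step of a 1.6-fold lower number from compound 1 to compound 2 (0.19 log units; within the scatter) is within the scatter, while compound 3 gives a lower number that is beyond it. Compound 4 `COc1cc(-c2nn(-c3cccc(NC(=O)Nc4cccc(C(F)(F)F)c4)c3)cc2-c2ccncc2)ccc1Cl` differs from compound 2 by (3-(trifluoromethyl)phenyl)amino in place of 3-(trifluoromethyl)phenyl on a carbonyl carbon. Within the data shown here, no measured step bears on this change; the only one, a 1.6-fold lower number from compound 1 to compound 2 (0.19 log units; within the scatter), concerns a different place and is within the scatter. Among the measured compounds shown here, compound 3, the only other compound carrying a urea, gives a lower number than compound 2, but it differs from compound 2 in more than one place, so it offers weak guidance. A modest step lower is therefore expected, a 1.8-fold lower number from compound 2 to compound 4 (0.25 log units; within the scatter), with wide uncertainty. Compound 4 is estimated at 800 nM, range 300 nM to 2500 nM.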

Compound 4, concentration for 50% growth inhibition: 751 nM
Beside the measured number, compound 4's estimate is 1.1-fold (0.03 log units) above it; measured number inside the range.
By their numbers in this assay, from the lowest: compounds 3, 4, 2 and 1 (each within the scatter of the next, the first and the last beyond it).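

In this assay, (3-(trifluoromethyl)phenyl)amino in place of 3-(trifluoromethyl)phenyl on the carbonyl carbon gives a 1.9-fold lower number from compound 2 to compound 4 (0.28 log units; within the scatter), so urea and amide cannot be told apart at this position. Against the 4-chloro-3-(trifluoromethyl)phenyl amide, the change gives a 3.0-fold lower number from compound 1 to compound 4 (0.47 log units; beyond the scatter), the first step at this position beyond the scatter, although it also removes the chloro. Nothing available explains either step. Still open, going by these compounds, is how a methylene or an ether oxygen would compare with the entering amino nitrogen. Also open, on these data alone, is how a chloro on the urea's aromatic ring would read.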